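The source may report more compounds than this note shows. Statements on the series, on what has been measured and on what is new or still open speak of the compounds shown alone.

Of the compounds shown here, three share the same sugar amide core and have been measured in a physicochemical assay for lipophilicity, measured as octanol-water partition; a lower number here means a more polar compound, a higher number a more lipophilic compound. Compound 1 `CC(C)c1ccc(/C=C/C(=O)N[C@@H]2O[C@H](CO)[C@@H](O)[C@H](O)[C@H]2O)cc1` gives 0.296, the highest of the three. Compound 2 `O=C(N[C@@H]1O[C@H](CO)[C@@H](O)[C@H](O)[C@H]1O)C1=Cc2cc(Cl)ccc2OC1` gives -0.169 in this assay, a number below that of compound 1 by more than the usual scatter. Compound 3 `Cc1ccc(-c2cnc(CCC(=O)N[C@@H]3O[C@H](CO)[C@@H](O)[C@H](O)[C@H]3O)o2)cc1` gives -0.574, the lowest of the three and further still below compound 1. Compound 4 `O=C(/C=C/c1ccc(-c2ccccc2)cc1)N[C@@H]1O[C@H](CO)[C@@H](O)[C@H](O)[C@H]1O` has not yet been measured in this assay. It differs from compound 1 in one place: phenyl in place of isopropyl on an aromatic carbon. Among the compounds with values here, no measured pair shows this change, so its size is not known from these data. The expected step is a number 0.40 log units higher from compound 1 to compound 4 (beyond the scatter), a rise beyond the scatter. Compound 4 is therefore estimated at 0.7, with a range from 0.3 to 1.1.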

Compound 4, partition coefficient: 0.851
Beside the measured number, compound 4's estimate is 0.15 log units below it; the measured number falls inside the stated range.
By their numbers in this assay, from the lowest: compound 3; then compound 2; then compound 1; then compound 4.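

In this assay, putting phenyl in place of isopropyl on this aromatic carbon, para to a large group, gives a number 0.56 log units higher from compound 1 to compound 4 (beyond the scatter), the first measured size for this change. The position therefore shows a modest rise when a six-membered aromatic ring of carbon only replaces a group with no ring. Nothing at hand explains the step, so the data give its size alone. The compounds shown leave open how an amine, a carboxylic acid or a longer chain on this carbon would compare. With a single pair, they also leave open whether this change gives a similar step elsewhere.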